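The source may report more compounds than this note shows. Statements on the series, on what has been measured and on what is new or still open speak of the compounds shown alone.

Measured so far:
compound 1 `CN(C)C(=O)c1cc2cnc(Nc3ccc(NC(=O)C4(C(=O)Nc5ccc(Cl)c(C(F)(F)F)c5)CC4)cc3)nc2n1C1CCCC1`: 88.1%
compound 2 `CN(C)C(=O)c1cc2cnc(Nc3ccc(NC(=O)C4(C(=O)Nc5cccc(Br)c5)CC4)cc3)nc2n1C1CCCC1`: 92.2%
compound 3 `COC(=O)c1cccc(NC(=O)C2(C(=O)Nc3ccc(Nc4ncc5cc(C(=O)N(C)C)n(C6CCCC6)c5n4)cc3)CC2)c1`: 91%

In a functional assay on A549 cells (Homo sapiens) for inhibition, read by CCK-8 assay, with a stated time of 72 h, tested at 10 uM (on this read-out higher numbers stand for more inhibition of growth at the one concentration tested and lower numbers for less inhibition of growth), compound 1 gives 88.1%, the lowest of the three numbers, though its gaps to compound 2 and to compound 3 both sit within the scatter. The unmeasured compound 4 `CN(C)C(=O)c1cc2cnc(Nc3ccc(NC(=O)C4(C(=O)Nc5cccc(C#N)c5)CC4)cc3)nc2n1C1CCCC1` differs from compound 1 by 3-cyanophenyl in place of 4-chloro-3-(trifluoromethyl)phenyl on an amide-type nitrogen. Within the data shown here, two measured steps bear on this change, both swapping the same group on the amide-type nitrogen for a smaller aryl: a number 4.1 percentage points higher from compound 1 to compound 2 (within the scatter) and a number 2.9 percentage points higher from compound 1 to compound 3 (within the scatter). Neither moved the read-out beyond the scatter, and the 3-bromophenyl and 3-(methoxycarbonyl)phenyl analogues are themselves within the scatter of each other (a number 1.2 percentage points lower from compound 2 to compound 3 (within the scatter)). A step of about a number 0.9 percentage points higher from compound 1 to compound 4 (within the scatter) is therefore expected, not beyond the scatter. Compound 4 is estimated at 89%, with a range of 78% to 96%.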

Compound 4, percent growth inhibition at one concentration: 73.6%
Estimate against measurement, compound 4: 15.4 percentage points above; measured number below the stated range.
By their numbers in this assay, from the lowest: compound 4; then compounds 1, 3 and 2 (each within the scatter of the next).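

In this assay, among these compounds, the aryl group on this amide-type nitrogen proves not to be indifferent: 3-cyanophenyl in place of 4-chloro-3-(trifluoromethyl)phenyl gives a number 14.5 percentage points lower from compound 1 to compound 4 (beyond the scatter), whereas no earlier pair left the scatter. Cyano also separates from both other substituents, with a number 17.4 percentage points lower from compound 3 to compound 4 (beyond the scatter) and a number 18.6 percentage points lower from compound 2 to compound 4 (beyond the scatter), so the tolerance seen among compounds 1, 2 and 3 does not cover every replacement. No measurement available here accounts for this difference.

On these data alone, whether the loss is particular to cyano remains open. A carboxylic acid or an aminomethyl group on the same phenyl ring would test that.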